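The source may hold more compounds than are shown below. What is called first, only, known or untested is meant among the compounds shown, and "the series" means these compounds.

Working notes on the series. Compound 1 `Cc1ccc(CS/C(=C/c2cc(C)ccc2C)C(=O)c2ccc(Cl)cc2)cc1` and compound 2 `Cc1ccc(CS/C(=C/c2sccc2C)C(=O)c2ccc(Cl)cc2)cc1` share one core and differ only in the aryl group on the double-bonded chain carbon. In a functional assay on DU-145 cells (Homo sapiens) for inhibition, read by trypan blue exclusion, with a stated time of 96 h (on this read-out lower numbers stand for stronger inhibition of growth and higher numbers for weaker inhibition of growth), compound 1 gives 10000 nM. In this assay compound 2 gives 10000 nM. The step of no change at the digits printed from compound 1 to compound 2 (within the scatter) shows that exchanging the aryl group at this position left the read-out where it was. Among the compounds with values here, compound 2 therefore stands level with compound 1 on the numbers so far, with no ordering between them.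

Compound 3 `Cc1ccc(CS/C(=C/c2ccc(Cl)cc2)C(=O)c2ccc(Cl)cc2)cc1` follows from compound 2 by 4-chlorophenyl in place of 3-methylthiophen-2-yl on a double-bonded chain carbon bound to a double-bonded chain carbon. Within the data shown here, the only step that bears on this change is the one from compound 1 to compound 2, which altered the same position without effect, so for compound 3 no step beyond the scatter is expected in this assay, meaning an expected step of no change at the digits printed from compound 2 to compound 3 (within the scatter). Compound 3 is estimated at 10000 nM, with a range from 5000 nM to 20000 nM.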

Compound 3, concentration for 50% growth inhibition: 10000 nM
Beside the measured number, compound 3's estimate shows no gap at the digits printed; the measured number falls inside the stated range.
By their numbers in this assay, from the lowest: compounds 1, 2 and 3 (each within the scatter of the next).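

In this assay, putting 4-chlorophenyl in place of 3-methylthiophen-2-yl gives no change at the digits printed from compound 2 to compound 3 (within the scatter), and putting it in place of 2,5-dimethylphenyl gives no change at the digits printed from compound 1 to compound 3 (within the scatter). The position on a double-bonded chain carbon bound to a double-bonded chain carbon has now carried three aryl groups, including a chlorine-bearing six-membered aromatic ring of carbon only, with no step beyond the scatter among them. No supporting data bear on why the read-out stays level across these groups.

From the compounds shown here alone, all three compounds carry an aromatic ring at this position, so it remains open whether an amine, a carboxylic acid or a longer chain there would shift the read-out. The compounds shown also leave open whether a change elsewhere on the shared core would move it from this level.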